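The compounds below may be only part of what the source reports. "The series", "measured", "known", "first", "only" and "open" are said of these compounds alone.

Compound 2 `O=C(Nc1cccc(-c2oc3cc(-c4ccc(F)cc4)ccc3c(=O)c2O)c1)c1ccc(C(F)(F)F)cc1` stands highest of the two numbers in a functional assay on MDA-MB-231 cells (Homo sapiens) for antiproliferative activity, read by CCK-8 assay, with a stated time of 72 h (on this read-out lower numbers stand for stronger inhibition and higher numbers for weaker inhibition), at 29400 nM; compound 1 `COc1ccccc1C(=O)Nc1cccc(-c2oc3cc(-c4ccc(F)cc4)ccc3c(=O)c2O)c1` gives 5110 nM in this assay. Within the data shown here, the one measured step, a 5.8-fold higher number from compound 1 to compound 2 (0.76 log units; beyond the scatter), exchanges the whole aryl group on the carbonyl carbon. Compound 3 `O=C(Nc1cccc(-c2oc3cc(-c4ccc(F)cc4)ccc3c(=O)c2O)c1)c1ccc(Br)cc1` carries a narrower change: bromo in place of trifluoromethyl on an aromatic carbon. Among the measured compounds shown here, no measured step bears directly on a swap of this kind on the 4-bromophenyl ring, so the expectation rests on compound 2 alone. Compound 3 is expected to stay close to compound 2, with a step of a 1.6-fold lower number from compound 2 to compound 3 (0.21 log units; within the scatter) not clearly beyond the scatter, estimated at 18000 nM within 6000 nM to 50000 nM.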

Compound 3, half-maximal inhibitory concentration: 24900 nM
Estimate against measurement, compound 3: 1.4-fold (0.14 log units) below, and the stated range covers the measured number.
By their numbers in this assay, from the lowest: compound 1; then compounds 3 and 2 (each within the scatter of the next).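

In this assay, bromo in place of trifluoromethyl on the aromatic carbon para to a large group gives a 1.2-fold lower number from compound 2 to compound 3 (0.07 log units; within the scatter), so this assay does not separate the two groups at this position. The change of aryl group on the carbonyl carbon gives a 4.9-fold higher number from compound 1 to compound 3 (0.69 log units; beyond the scatter), which puts the 4-bromophenyl compound on the same side of compound 1 as the 4-(trifluoromethyl)phenyl compound. Nothing available bears on the cause of either step.

As far as these compounds go, whether an amine or a carboxylic acid in place of bromo would separate from compound 2 and compound 3 stays open. Also open, from the compounds shown here alone, is whether the gap to compound 1 follows the methoxy group itself or its place on the ring.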